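A few compounds are considered here, and "the series" means these few. Any claim that something is new, unique, unknown or untested is made for them only; others in the source may bear on it.

Compound 1 `O=C(Nc1ccc(F)cc1)N1N=C(c2ccc(Br)cc2)CC1c1ccc(F)cc1` in an assay on HEK293 cells for inhibition of Voltage-dependent L-type calcium channel subunit alpha-1C (Homo sapiens), read by FLIPR and calcium flux, with a stated time of 3 min (on this read-out lower numbers stand for stronger inhibition and higher numbers for weaker inhibition), gives > 10000 nM, a limit of the assay.
Compound 2 `COc1ccc(NC(=O)N2N=C(c3ccc(Br)cc3)CC2c2ccc(F)cc2)cc1` in this assay gives > 10000 nM, also a limit.

Compound 2 therefore stands only at the limit of the read-out, and the step that the two limits leave unreadable from compound 1 to compound 2 cannot be read, since both values sit at the limit of > 10000 nM in this assay, at which 2 of the 2 values shown sit. Compound 3 `O=C(NC1CCCCC1)N1N=C(c2ccc(Br)cc2)CC1c1ccc(F)cc1` differs from compound 2 by cyclohexyl in place of 4-methoxyphenyl on an amide-type nitrogen. For the measured compounds named here, no measured step bears on a change of this kind, and the single measured step is unreadable, so no direction can be taken from it. Compound 3 is expected to remain near the limit, estimated at 15000 nM with a range from 3000 nM to 60000 nM. The implied step that the limit leaves unreadable from compound 2 to compound 3 is expected not to be readable beyond the scatter.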

Compound 3, half-maximal inhibitory concentration: 1340 nM
Beside the measured number, compound 3's estimate is 11-fold (1.05 log units) above it; measured number below the stated range.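

The amide-type nitrogen is a position where the substituent changes the read-out in this assay: cyclohexyl in place of 4-methoxyphenyl gives a readable value (an at least 7.4-fold lower number from compound 2 to compound 3 (0.87 log units; beyond the scatter)), and cyclohexyl in place of 4-fluorophenyl does the same (an at least 7.4-fold lower number from compound 1 to compound 3 (0.87 log units; beyond the scatter)). The step between the two aryl compounds cannot be read. The true size of both new steps also stays open because the aryl values are limits: the limit of > 10000 nM in this assay, at which 2 of the 3 values shown sit.

On these data alone, a single non-aromatic ring carries this result, so it remains open whether cyclopentyl, a longer chain such as n-hexyl, or a cyclohexyl ring bearing an amine would hold, raise or lose the value. As far as these compounds go, the effect of this change on other parts of the shared core also remains open.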